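The source may hold more compounds than are shown below. What is called first, only, known or untested is meant among the compounds shown, and "the series" means these compounds.

In a functional assay on DU-145 cells (Homo sapiens) for cytotoxicity, read by trypan blue exclusion, with a stated time of 96 h (a higher number here means a weaker inhibitor, a lower number a stronger inhibitor), compound 1 `COc1ccc(NS(=O)(=O)/C=C/c2c(OC)cc(OC)cc2OC)cc1` gives 200 nM, compound 2 `COc1cc(OC)c(/C=C/S(=O)(=O)Nc2ccc(OC)c(OP(=O)(O)O)c2)c(OC)c1` gives 40 nM and compound 3 `COc1cc(OC)c(/C=C/S(=O)(=O)Nc2ccc(OC)c(N)c2)c(OC)c1` gives 5 nM, the lowest of the three numbers. Compound 4 `COC(=O)CNc1cc(NS(=O)(=O)/C=C/c2c(OC)cc(OC)cc2OC)ccc1OC` differs from compound 3 by (methoxycarbonyl)methyl in place of hydrogen on a nitrogen on an aromatic ring. Going by the values given here, no measured step changes that nitrogen's substituents, so the evidence is indirect. Adding the amino group gave a large step, a 40-fold lower number from compound 1 to compound 3 (1.60 log units; beyond the scatter), while the phosphorus-bearing group gave a modest one, a 5.0-fold lower number from compound 1 to compound 2 (0.70 log units; beyond the scatter), and exchanging it for amino gave an 8.0-fold lower number from compound 2 to compound 3 (0.90 log units; beyond the scatter). A modest step to a higher number in this assay is therefore expected, estimated as a 3.0-fold higher number from compound 3 to compound 4 (0.48 log units; beyond the scatter). The estimate for compound 4 is 15 nM, with an expected range of 4 nM to 60 nM.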

Compound 4, half-maximal inhibitory concentration: 350 nM
Estimate against measurement, compound 4: 23-fold (1.37 log units) below; the whole stated range lies below it.
By their numbers in this assay, from the lowest: compound 3; then compound 2; then compounds 1 and 4 (each within the scatter of the next).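

In this assay, placing (methoxycarbonyl)methyl on the nitrogen removes the large gain that amino brought (a 70-fold higher number from compound 3 to compound 4 (1.85 log units; beyond the scatter)), so the low number depends strongly on what this nitrogen carries. The substituted compound also stands on the weaker side of the phosphorus-bearing one (an 8.8-fold higher number from compound 2 to compound 4 (0.94 log units; beyond the scatter)), while ((methoxycarbonyl)methyl)amino shows no real difference from hydrogen on the aromatic carbon (a 1.8-fold higher number from compound 1 to compound 4 (0.24 log units; within the scatter)). Going by these compounds, whether a methyl, an acetyl or a free carboxylic acid on this nitrogen would keep the number of compound 3 stays open. No measurement here offers a reason for the loss.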